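Swapping ring methyls for an amine on the sulfonyl arene

The source may report more compounds than this note shows. Statements on the series, on what has been measured and on what is new or still open speak of the compounds shown alone.

Of the compounds shown here, three have been measured in a functional assay on DLD-1 cells (Homo sapiens) for antiproliferative activity, read by CellTiter-Glo, with a stated time of 72 h; a lower number here means a stronger inhibitor, a higher number a weaker inhibitor. Compound 2 `Cc1ccc(S(=O)(=O)N2CCC(N3CCC(C)CC3)CC2)cc1C` gives 24 nM, the lowest number of the three. Compound 1 `COc1ccc(S(=O)(=O)N2CCC(N3CCC(C)CC3)CC2)cc1OC` gives 138 nM, a higher number that lies beyond the scatter. Compound 3 `Cc1ccc(C2CCN(S(=O)(=O)c3c(C)cc(C)cc3C)CC2)cc1`, built on a different core, gives 2200 nM, the highest of the set and well beyond the scatter from compound 2. Compound 4 `CC1CCN(C2CCN(S(=O)(=O)c3cccc(N)c3)CC2)CC1` has not yet been measured; its change from compound 2 is 3-aminophenyl in place of 3,4-dimethylphenyl on a sulfonyl sulfur. For the measured compounds named here, no measured pair shows this change directly, so the size of the step is uncertain. Compound 4 is expected to be a weaker inhibitor, with the step of an 8.3-fold higher number from compound 2 to compound 4 (0.92 log units; beyond the scatter) estimated to reach beyond the scatter. In this assay compound 4 is expected to give 200 nM, within a range from 50 nM to 1000 nM.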

Compound 4, half-maximal inhibitory concentration: 3400 nM
Compound 4: middle estimate off by 17-fold (1.23 log units), on the low side; measured number outside the range, above it.
By their numbers in this assay, from the lowest: compound 2; then compound 1; then compounds 3 and 4 (each within the scatter of the next).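

For the compounds shown here, this is the first direct reading at this position: in this assay, putting 3-aminophenyl in place of 3,4-dimethylphenyl on a sulfonyl sulfur gives a 140-fold higher number from compound 2 to compound 4 (2.15 log units; beyond the scatter) and so counts as a large loss. On this shared core, then, the two aryl groups are far from interchangeable. Nothing available accounts for the size of this loss.

On these data alone, the swap removes both methyls and adds the amine in one change, so their separate contributions stay open. A 3-methylphenyl group or a 3-amino-4-methylphenyl group at this position would begin to separate them.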